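Trimming the proline nitrogen substituent to a methyl

The source may hold more compounds than are shown below. What is called first, only, known or untested is meant among the compounds shown, and "the series" means these compounds.

Measured so far:
- compound 1, `CN(C)c1ccc(C(=O)N2CCC[C@H]2C(=O)N2CCC(NS(=O)(=O)c3cc(S(=O)(=O)c4ccccc4)ccc3C(F)(F)F)CC2)cc1`: 110 nM
- compound 2, `O=C([C@@H]1CCCN1C(=O)Nc1ccccc1)N1CCC(NS(=O)(=O)c2cc(S(=O)(=O)c3ccccc3)ccc2C(F)(F)F)CC1`: 20 nM

In an assay on isolated protein for binding affinity to secreted frizzled-related protein 1 (Homo sapiens), read by fluorescence (on this read-out higher numbers stand for weaker inhibition and lower numbers for stronger inhibition), compound 2 gives 20 nM, the lowest of the two numbers seen so far. Within the data shown here, its nearest neighbour is compound 1, which gives 110 nM in this assay; the only measured step, a 5.5-fold lower number from compound 1 to compound 2 (0.74 log units; beyond the scatter), is modest but beyond the scatter.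

Compound 3, `CN1CCC[C@H]1C(=O)N1CCC(NS(=O)(=O)c2cc(S(=O)(=O)c3ccccc3)ccc2C(F)(F)F)CC1`, has not been measured yet. It differs from compound 2 in one place: methyl in place of phenylcarbamoyl on an amine nitrogen in a ring. The group that is cut away is large, with an aromatic ring and both a hydrogen-bond donor and acceptor; what enters is a single carbon.

Among the measured compounds shown here, no measured step tests the loss of this whole group. The step from compound 1 to compound 2 only swaps one aryl cap for another while the carbonyl stays, so it bears on the change only loosely. Taking the loss of that much structure as more likely to weaken than to strengthen binding, compound 3 is expected to show a step of a 13-fold higher number from compound 2 to compound 3 (1.10 log units; beyond the scatter), giving an estimated value of 250 nM with a range from 40 nM to 1500 nM.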

Compound 3, half-maximal inhibitory concentration: 120 nM
Compound 3: middle estimate off by 2.1-fold (0.32 log units), on the high side, within the range that was stated.
By their numbers in this assay, from the lowest: compound 2; then compounds 1 and 3 (each within the scatter of the next).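

In this assay, among these compounds, putting methyl in place of phenylcarbamoyl on the ring nitrogen gives a 6.0-fold higher number from compound 2 to compound 3 (0.78 log units; beyond the scatter) and is the first direct test of this group, showing that the lower number of compound 2 depends on what sits at this position. The other large group behaves differently: methyl in place of (4-(dimethylamino)phenyl)carbonyl gives a 1.1-fold higher number from compound 1 to compound 3 (0.04 log units; within the scatter) and leaves the number within the scatter, so a large group here does not by itself give a lower number than a single carbon does. No measurement in hand explains why these two large groups differ.

As far as these compounds go, what remains open is which part of the phenylcarbamoyl group matters, the aromatic ring or the carbonyl with its amide hydrogen. A methylcarbamoyl group, which keeps the carbonyl and the amide hydrogen but has no aromatic ring, and a benzyl group, which keeps an aromatic ring but has no carbonyl, would help to separate these parts.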